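Chloro step in the writhing series: working notes

This account rests on a few compounds, and the source may have more. Where it says the series, first, only, none or still open, it means among the compounds named here.

Measured so far, in a functional assay on the whole organism (Abdomen, strain Swiss albino) for inhibition, with Mus musculus as the target, in the writhing test, with a stated time of 30 min, at a dose of 30 mg/kg by the oral route; a lower number here means less inhibition, a higher number more inhibition at the dose given (going by the name of the read-out):
compound 1 `O=C(O)[C@H]1CCC[C@@H](c2cccc3ccccc23)O1` gives 49%;
compound 2 `OC[C@H]1CCC[C@@H](c2cccc3ccccc23)O1` gives 39.2%;
compound 3 `CC(C)C(=O)OC[C@H]1C[C@@H](Cl)C[C@@H](c2ccc3ccccc3c2)O1` gives 44.4%.

Compound 2 has the lowest of the three numbers in this assay, but its gaps to compound 3 and to compound 1 both lie within the scatter, so no order can be read among them. Compound 4 `OC[C@H]1C[C@@H](Cl)C[C@@H](c2cccc3ccccc23)O1` differs from compound 2 by chloro in place of hydrogen on a saturated ring carbon. For the measured compounds named here, the only step measured in one place, a number 9.8 percentage points lower from compound 1 to compound 2 (within the scatter), concerns hydroxymethyl against carboxy and does not touch the chloro change. Going by the values given here, compound 3 carries a chloro group but differs from compound 2 in more than one place, so its value shows only that a chloro-bearing member sits within the scatter of compound 2. No step beyond the scatter is therefore expected in this assay, and a number 2.8 percentage points higher from compound 2 to compound 4 (within the scatter) is the estimated step. Compound 4 is expected to give 42%, between 30% and 54%.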

Compound 4, a percentage reported as inhibition, in the whole organism at one dose (the size of the read-out at that dose, not a potency): 87.5%
Estimate against measurement, compound 4: 45.5 percentage points below; measured number above the stated range.
By their numbers in this assay, from the lowest: compounds 2, 3 and 1 (each within the scatter of the next); then compound 4.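

Chloro in place of hydrogen on this saturated ring carbon, two ring bonds from the ring atom that bears a hydroxymethyl group, comes with a number 48.3 percentage points higher from compound 2 to compound 4 (beyond the scatter) in this assay. For the compounds shown here, this is the first step beyond the scatter, and it shows that this position responds strongly to a change of one heavy atom. Nothing available accounts for the size of this step.

On these data alone, whether bromo or an amine on the same ring carbon would give a comparable step remains open. Also open, as far as these compounds go, is whether chloro would act alike with carboxy in place of hydroxymethyl.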